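The source may hold more compounds than are shown below. What is called first, only, known or untested is meant among the compounds shown, and "the series" means these compounds.

Measured compounds:
compound 1, `CC1=C(N2CC2)C(=O)C(Cc2ccccc2)=C(N2CC2)C1=O`: 4.85
compound 2, `COCCOC(COC(N)=O)C1=C(N2CC2)C(=O)C(C)=C(N2CC2)C1=O`: 6.03
compound 3, `CCCC1=C(N2CC2)C(=O)C(CCOC(N)=O)=C(N2CC2)C1=O`: 5.68

In a functional assay on L1210 cells (Mus musculus), with a stated time of 12 days (on this read-out higher numbers stand for higher potency (the scale is a negative logarithm) and lower numbers for lower potency), compound 1 gives the lowest of the three numbers. The nearest is compound 3, whose value lies beyond the scatter above it, and the furthest is compound 2, also beyond the scatter above it. Compound 4, `CCC(OC)C1=C(N2CC2)C(=O)C(C)=C(N2CC2)C1=O`, has not yet been measured. It differs from compound 1 by 1-methoxypropyl in place of benzyl on a double-bonded ring carbon. Among the compounds with values here, no step between measured compounds matches this change, so the expectation rests on what the three numbers show: both compounds carrying an oxygen-bearing chain stand higher than compound 1. Compound 4 is therefore expected to gain potency, by a step of a number 0.65 log units higher from compound 1 to compound 4 (beyond the scatter), beyond the scatter. The estimate for compound 4 is 5.5, with a range from 4.9 to 6.2.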

Compound 4, logarithm of the reciprocal of the active concentration, log(1/C): 5.68
Beside the measured number, compound 4's estimate is 0.18 log units below it; low and high end bracket the measured number.
By their numbers in this assay, from the lowest: compound 1; then compounds 3 and 4 (each within the scatter of the next); then compound 2.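

In this assay, within the data shown here, 1-methoxypropyl in place of benzyl on a double-bonded ring carbon gives a number 0.83 log units higher from compound 1 to compound 4 (beyond the scatter), the first reading of a single change at this position. The position therefore accepts a chain with no ring and one hydrogen-bond acceptor in place of the aromatic ring of benzyl, with a gain rather than a loss. Nothing measured here accounts for this gain.

The compounds shown do not separate the loss of the aromatic ring from the entry of the ether oxygen. Also open, going by these compounds, is what a plain butyl chain, a 1-hydroxypropyl group or an amine-bearing chain would give on the same carbon.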